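Fluorine on the sulfonyl aryl of compound 2

The source may report more compounds than this note shows. Statements on the series, on what has been measured and on what is new or still open speak of the compounds shown alone.

For the measured compounds named here, compound 2 `O=C1O[C@H]([C@@H](O)Cn2cc(CNS(=O)(=O)c3ccc(Cl)cc3)nn2)C(OCc2ccccc2)=C1OCc1ccccc1` gives the lowest of the two numbers so far in a functional assay on CFPAC-1 cells (Homo sapiens) for antiproliferative activity, read by MTT assay, with a stated time of 72 h (a higher number here means a weaker inhibitor, a lower number a stronger inhibitor), with 38900 nM. Compound 1 `O=C1O[C@H]([C@@H](O)Cn2cc(-c3cccc(O)c3)nn2)C(OCc2ccccc2)=C1OCc1ccccc1` is its nearest neighbour in this assay. In this assay compound 1 gives 54100 nM, and the change a 1.4-fold lower number from compound 1 to compound 2 (0.14 log units; within the scatter) stays within the scatter. Compound 3 `O=C1O[C@H]([C@@H](O)Cn2ccnn2)C(OCc2ccccc2)=C1OCc1ccccc1`, the bare parent, reaches only the assay limit in this assay, > 100000 nM. The steps of an at least 1.8-fold higher number from compound 1 to compound 3 (0.26 log units; that floor lies within the scatter) and an at least 2.5-fold higher number from compound 2 to compound 3 (0.41 log units; beyond the scatter) show that the whole arm on the triazole is what lifts the series off that limit.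

Compound 4 `O=C1O[C@H]([C@@H](O)Cn2cc(CNS(=O)(=O)c3ccc(Cl)cc3F)nn2)C(OCc2ccccc2)=C1OCc1ccccc1` differs from compound 2 by fluoro in place of hydrogen on an aromatic carbon. Going by the values given here, no measured step touches the 4-chlorophenyl ring itself; the steps seen so far swap or remove the entire arm, so they set only the scale of the series, not this small edit. The expected step of a 1.1-fold lower number from compound 2 to compound 4 (0.05 log units; within the scatter) is therefore none beyond the scatter. Compound 4 is estimated at 35000 nM in this assay, within 15000 nM to 80000 nM.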

Compound 4, half-maximal inhibitory concentration: 58200 nM
Compound 4: middle estimate off by 1.7-fold (0.22 log units), on the low side, within the range that was stated.
By their numbers in this assay, from the lowest: compounds 2, 1 and 4 (each within the scatter of the next). At a limit, above all of these: compound 3.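

The first edit on the 4-chlorophenyl ring itself, fluoro in place of hydrogen ortho to a large group and meta to a chloro group, gives in this assay a 1.5-fold higher number from compound 2 to compound 4 (0.17 log units; within the scatter), so no direction can be claimed for it. For the compounds shown here, this position therefore accepts a single fluoro without a change beyond the scatter, a finer reading than the earlier steps gave, since those swapped or removed the whole arm. Nothing at hand bears on why this fluoro leaves the number within the scatter.

On these data alone, whether a larger group at this position, such as a methoxy group or an amine, would give a step beyond the scatter remains open. So does the part played by the chloro group, which a hydrogen or a nitrile in its place would test.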